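Replacing the amidoxime-bearing group on compound 3

A few compounds are considered here, and "the series" means these few. Any claim that something is new, unique, unknown or untested is made for them only; others in the source may bear on it.

Of the compounds shown here, three have been measured in a functional assay (blood) for inhibition, with Homo sapiens as the target; a lower number here means a stronger inhibitor, a higher number a weaker inhibitor. Compound 1, `COC1(c2cc(F)cc(Sc3ccc4c(c3)CC/C4=N\OCC#N)c2)CCOCC1`, gives 30 nM in this assay. Compound 2, `CO[C@]1(c2cc(F)cc(S(=O)(=O)c3ccc(/C(C)=N/OCC#N)cc3)c2)CCO[C@@H](C)C1`, gives 60 nM. Compound 3, `CN(C)/C(=N\O)c1ccc(Sc2cc(F)cc(C3CCOCC3)c2)cc1`, gives 280 nM, the highest number of the three: its nearest neighbour is compound 2, whose number is lower by a margin beyond the scatter, and compound 1 lies further still below it. Compound 3 is therefore the weakest inhibitor among the measured compounds.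

Compound 4, `CCOC(=O)CO/N=C(\C)c1ccc(Sc2cc(F)cc(C3CCOCC3)c2)cc1`, has not yet been measured. It differs from compound 3 in one place, on an aromatic carbon of a six-membered aromatic ring of carbon only, para to a large group: a group of 10 heavy atoms (6 carbon, 1 nitrogen, 3 oxygen; no ring) in place of a group of 6 heavy atoms (3 carbon, 2 nitrogen, 1 oxygen; no ring), on an aromatic carbon. The group that enters resembles the oxime ether carried by compound 1 and compound 2, both of which give lower numbers than compound 3.

For the measured compounds named here, on that basis compound 4 is expected to show a moderate downward step in this assay, a 3.1-fold lower number from compound 3 to compound 4 (0.49 log units; beyond the scatter), though no measured pair isolates this change. The estimate for compound 4 is 90 nM, with a plausible range from 25 nM to 300 nM.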

Compound 4, half-maximal inhibitory concentration: 610 nM
For compound 4 the middle estimate is 6.8-fold (0.83 log units) below the measured one, outside the stated range (above it).
By their numbers in this assay, from the lowest: compounds 1 and 2 (each within the scatter of the next); then compound 3; then compound 4.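

In this assay, the exchange on this aromatic carbon gives a 2.2-fold higher number from compound 3 to compound 4 (0.34 log units; beyond the scatter), so the group of 10 heavy atoms does not improve on the group of 6 heavy atoms it replaces. This first one-place comparison shows that a resemblance to the group on compound 1 and compound 2 does not by itself bring a lower number to the core of compound 3. The change removes the hydrogen-bond donor and adds acceptors as well as size, and no available evidence bears on which of these differences, if any, lies behind the step.

Going by these compounds, it remains open whether size or the count of donors and acceptors governs this position. On these data alone, it is also open how the position would respond to a chain ending in a carboxylic acid or an amine.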